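Methylation of the hydroxy group in a diterpenoid lactone series

The compounds below may be only part of what the source reports. "The series", "measured", "known", "first", "only" and "open" are said of these compounds alone.

Measured compounds:
- compound 1, `C=C1CC[C@H]2C(C)(C)CCC[C@]2(C)[C@H]1C[C@@H](O)C1=CCOC1=O`, 84%
- compound 2, `C=C1CC[C@H]2C(C)(C)CCC[C@]2(C)[C@H]1C/C=C1\CC(O)OC1=O`, 82.4%

Both measured compounds share a core and differ in the lactone portion. In a functional assay on RAW264.7 cells (Mus musculus) for inhibition, read by ELISA, with stated times of 1 h and 18 h, tested at 1 uM (a higher number here means a weaker effect of the compound at the concentration tested, a lower number a stronger effect), compound 1 gives 84%. Compound 2 in this assay gives 82.4%. The two numbers lie within the scatter of each other, so on what has been measured compound 2 and compound 1 behave alike, and neither can be called the stronger or weaker of the pair.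

Compound 3, `C=C1CC[C@H]2C(C)(C)CCC[C@]2(C)[C@H]1C/C=C1\CC(OC)OC1=O`, is not yet measured. It differs from compound 2 by methyl in place of hydrogen on an oxygen on a saturated carbon. Among the measured compounds shown here, no step between measured compounds that change in one place is available, so there is no measured precedent for the size of this change in this assay.

Given that both measured values sit near the same level, the step from compound 2 to compound 3 is expected to be small, likely none beyond the scatter, with no direction favoured: a number 0.4 percentage points lower from compound 2 to compound 3 (within the scatter) is the expected step. Compound 3 is accordingly estimated to give 82% in this assay, within a range from 65% to 96%.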

Compound 3, a percentage reported as activity, at one concentration (the size of the read-out at that concentration, not a potency): 79.1%
Compound 3: middle estimate off by 2.9 percentage points, on the high side; the range from low to high includes it.
By their numbers in this assay, from the lowest: compounds 3, 2 and 1 (each within the scatter of the next).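

Among the compounds shown here, the first step that changes one place, hydroxy to methoxy, reads in this assay as a number 3.3 percentage points lower from compound 2 to compound 3 (within the scatter). At this position, on an oxygen on a saturated carbon, methyl can therefore take the place of hydrogen without moving the read-out beyond the scatter, so the free hydroxy group is not needed to hold the level seen for compound 2 in this read-out. No measurement at hand bears on what lies behind this step, and the size of the step is all that can be stated.

From the compounds shown here alone, it remains open whether the position would tolerate a group larger than methyl to the same degree, such as a longer alkyl chain or a benzyl ether, or whether replacing the oxygen with an amine would leave the number at this level. These read-outs also come from one concentration and are not potencies, so a difference between compound 2 and compound 3 that is hidden at this concentration could still exist at another.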